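A Change of Configuration at One Ring Carbon

This account rests on a few compounds, and the source may have more. Where it says the series, first, only, none or still open, it means among the compounds named here.

Of the compounds shown here, three have so far been measured in an assay on Sf9 cells for inhibition of histone deacetylase 11 (Homo sapiens), read by fluorescence, tested at 0.5 uM; on this read-out lower numbers stand for less inhibition and higher numbers for more inhibition at the one concentration tested (going by the name of the read-out). Compound 1 `O=C(NO)c1cccc(-c2cn([C@@H]3C[C@@H](CO)N(Cc4ccccc4)C3)nn2)c1` gives < 10% in this assay, and this figure is a limit of the assay rather than a measured number. Compound 2 `O=C(NO)c1ccc(-c2cn([C@H]3C[C@H](C(=O)O)N(CCCc4ccccc4)C3)nn2)cc1` returns < 10% in this assay, which is likewise a limit. Compound 3 `O=C(NO)c1ccc(-c2cn([C@H]3C[C@@H](C(=O)O)N(Cc4ccccc4)C3)nn2)cc1` gives < 10% in this assay, again a limit. Every value recorded therefore sits at the same floor, and no ordering among the three compounds can be drawn from them: the limit of < 10% in this assay, at which 3 of the 3 values shown sit.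

Compound 4 `O=C(NO)c1cccc(-c2cn([C@H]3C[C@@H](CO)N(Cc4ccccc4)C3)nn2)c1` has not yet been measured. It stands apart from compound 1 in configuration only: the two compounds have the same atoms and bonds and differ only in configuration as drawn: 1 of 2 stereo elements differ; a stereocentre at a saturated ring carbon is drawn R in compound 1 and S in compound 4.

For the measured compounds named here, every value so far is a limit. Going by the values given here, no measured step exists to set the size of a change on this assay. Compound 1 stands at the floor of the assay, and its three companions stand there too. The step expected on this assay is a step that the limit leaves unreadable from compound 1 to compound 4, that is, nothing beyond the scatter. Compound 4 is accordingly expected to give 5% in this assay, with the estimate spanning 0% to 15%, and most probably reported once more only as a limit.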

Compound 4, a percentage reported as inhibition, at one concentration (the size of the read-out at that concentration, not a potency): < 10%
Compound 4: only a limit was reported; the forecaster's own chance of this, stated with the estimate: 80%; the middle value does not contradict the limit.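

Compound 4 gives < 10% in this assay, and this is a limit of the assay, not a number. Compound 1 also sits at a limit, so no step can be read between compound 1 and compound 4. The compounds shown leave open whether the configuration at this ring carbon affects inhibition in this assay: the limit of < 10% in this assay, at which 4 of the 4 values shown sit.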